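The source may hold more compounds than are shown below. What is called first, only, known or untested is meant among the compounds shown, and "the series" means these compounds.

Within the data shown here, compound 1 `Cc1ccc(NC(=S)NC(=O)c2ccc(OCc3cccc(Cl)c3Cl)cc2)cc1-c1nc2ccccc2[nH]1` is one of two compounds measured in this study. In a functional assay on MGC-803 cells (Homo sapiens) for inhibition, read by MTT assay, with a stated time of 48 h (a higher number here means a weaker inhibitor, a lower number a stronger inhibitor), compound 1 gives only a limit, > 100000 nM. Among the measured compounds shown here, compound 2 `Cc1ccc(NC(=O)NC(=O)c2ccc(OCc3ccccc3)cc2)cc1-c1nc2ccccc2[nH]1` gives in this assay a value of 39400 nM, the only actual number among the two values shown. Compound 3 `Cc1ccc(COc2ccc(C(=O)NC(=O)Nc3ccc(C)c(-c4nc5ccccc5[nH]4)c3)cc2)cc1` differs from compound 2 by methyl in place of hydrogen on an aromatic carbon, a methyl in place of hydrogen on an aromatic carbon. For the measured compounds named here, no measured step of this kind is available, so any shift is expected to stay within the usual scatter. Compound 3 is therefore estimated at 30000 nM in this assay, between 12000 nM and 80000 nM. The expected step of a 1.3-fold lower number from compound 2 to compound 3 (0.12 log units; within the scatter) is small.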

Compound 3, half-maximal inhibitory concentration: 4250 nM
Compound 3: middle estimate off by 7.1-fold (0.85 log units), on the high side, and the stated range ends above it.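

In this assay the change from benzyl to 4-methylbenzyl gives a 9.3-fold lower number from compound 2 to compound 3 (0.97 log units; beyond the scatter) and so shows that this position is not indifferent to substitution. A methyl para to a large group, a single added carbon, is enough to move the read-out beyond the scatter. Nothing measured here accounts for the size of this step.

The compounds shown leave open whether a methoxy group, a chlorine atom or a longer chain at this place would go further in the same direction. They also leave open what a carboxylic acid or an amine would do there.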